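This account rests on a few compounds, and the source may have more. Where it says the series, first, only, none or still open, it means among the compounds named here.

Compound 1 `Clc1ccc(CO/N=C/c2c(-c3ccc(Br)cc3)nc3sccn23)cc1Cl` gives 480 nM in an assay on HepG2 cells for agonist activity at nuclear receptor subfamily 1 group I member 3 (Homo sapiens), read by a luciferase reporter, with a stated time of 23 h; on this read-out lower numbers stand for an effect already at smaller amounts and higher numbers for an effect only at larger amounts of compound
Compound 2 `CC(C)(C)c1ccc(-c2nc3sccn3c2/C=N/OCc2ccc(Cl)c(Cl)c2)cc1` gives 2400 nM in this assay

Compound 2 holds the highest of the two numbers shown in this assay; its nearest neighbour is compound 1, and the only step measured here is a 5.0-fold higher number from compound 1 to compound 2 (0.70 log units; beyond the scatter), which moved the number beyond the scatter. Compound 3 `FC(F)(F)c1ccc(-c2nc3sccn3c2/C=N/OCc2ccc(Cl)c(Cl)c2)cc1` has not been measured. It differs from compound 2 in one place: trifluoromethyl in place of tert-butyl on an aromatic carbon. Within the data shown here, no measured pair shows this exchange, so the one step that bears on it is a 5.0-fold higher number from compound 1 to compound 2 (0.70 log units; beyond the scatter), which tells only that the tert-butyl group carries a higher number than bromo on the same aromatic carbon. Since the entering trifluoromethyl is neither of these two groups, a modest shift in either direction is possible, and the expectation is a number somewhat lower than compound 2 but not as low as compound 1, so that a 2.2-fold lower number from compound 2 to compound 3 (0.34 log units; beyond the scatter) is the step expected. Compound 3 is therefore estimated at 1100 nM in this assay, with a range from 400 nM to 3200 nM.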

Compound 3, half-maximal effective concentration: 880 nM
Compound 3: middle estimate off by 1.3-fold (0.10 log units), on the high side, within the range that was stated.
By their numbers in this assay, from the lowest: compounds 1 and 3 (each within the scatter of the next); then compound 2.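

At the 4-substituted phenyl ring, the exchange of tert-butyl for trifluoromethyl gives a 2.7-fold lower number from compound 2 to compound 3 (0.44 log units; beyond the scatter) in this assay, so two groups with the same count of heavy atoms, neither carrying a hydrogen-bond donor or acceptor, are told apart at this position. Among these compounds, the second comparison, a 1.8-fold higher number from compound 1 to compound 3 (0.26 log units; within the scatter), shows that bromo and trifluoromethyl cannot be told apart here, which leaves tert-butyl as the only one of the three groups whose steps to both others lie beyond the scatter. No measurement shown here accounts for the difference between these groups, so the data record the shift without explaining it.

As far as these compounds go, all three compounds carry a halogen-containing or purely carbon group at this one position, so it remains open how the number would respond to a bare hydrogen, a methoxy group, an amine or a carboxylic acid in the same place. The rest of the molecule is identical across the three compounds, so these steps also say nothing about whether the same order of groups would hold with a different substituent on the dichlorobenzyl part or with another core.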